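Replacing phenyl with pyrimidin-5-yl on compound 2

This account rests on a few compounds, and the source may have more. Where it says the series, first, only, none or still open, it means among the compounds named here.

Compound 1 `O=c1nc(-c2ccccc2)c2cc(-c3ccc(N4CCCC4)nc3)ccc2[nH]1`: > 50000 nM (a limit)
Compound 2 `O=c1nc(-c2ccccc2)c2cc(-c3ccccc3)ccc2[nH]1`: > 50000 nM (a limit)
Compound 3 `CNC(=O)c1cccc(-c2ccc3[nH]c(=O)nc(-c4ccccc4)c3c2)c1`: > 50000 nM (a limit)

All three compounds were tested in an ADME assay on THP-1 cells (Homo sapiens) for cytotoxicity, read by MTT assay, with a stated time of 72 h (on this read-out higher numbers stand for an effect only at larger amounts of compound and lower numbers for an effect already at smaller amounts), and none of them gave a number. Compound 2 stands at > 50000 nM, which is a limit of the assay and not a number. The whole set shares that position, with the limit of > 50000 nM in this assay, at which 3 of the 3 values shown sit.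

Compound 4 `O=c1nc(-c2ccccc2)c2cc(-c3cncnc3)ccc2[nH]1` has not yet been measured. Its difference from compound 2 is this: pyrimidin-5-yl in place of phenyl on an aromatic carbon. In words, pyrimidin-5-yl stands in place of phenyl on an aromatic carbon.

Going by the values given here, only one measured step bears on this change, a step that the two limits leave unreadable from compound 2 to compound 3, and it has no readable size. Neither compound 1 nor compound 3 left the limit in this assay. No step beyond the scatter is therefore expected, and no direction can be given. The expected step is a number no higher from compound 2 to compound 4 (the limit leaves the size open). Compound 4 is most likely to be reported as a limit again. For compound 4 the estimated value is 50000 nM, with an expected range from 25000 nM to 100000 nM.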

Compound 4, half-maximal effective concentration: > 50000 nM
Compound 4 ended at the assay's limit; the forecaster's own chance of this, stated with the estimate: 85%; the middle value lies on the limit itself.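

Going by these compounds alone, compound 2 and compound 4 both sit at a limit of the assay, so no step between them can be read, and pyrimidin-5-yl in place of phenyl has no readable size in this assay. The compounds shown leave open at what concentration, if any, cytotoxicity would appear, as all share one position: the limit of > 50000 nM in this assay, at which 4 of the 4 values shown sit.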